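Moving fluorine on the aryl ketone of a triazole series

The compounds below may be only part of what the source reports. "The series", "measured", "known", "first", "only" and "open" are said of these compounds alone.

Compound 1 `COc1cc(-c2nnc(SCC(=O)c3ccc(Br)cc3)n2N)cc(OC)c1OC` in a functional assay on HepG2 cells (Homo sapiens) for antiproliferative activity, read by MTT assay, with a stated time of 48 h (on this read-out lower numbers stand for stronger inhibition and higher numbers for weaker inhibition), gives 92500 nM. Compound 2 `COc1cc(-c2nnc(SCC(=O)c3ccc(C(F)(F)F)cc3)n2N)cc(OC)c1OC` gives only a limit of this assay, > 100000 nM. Compound 3 `COc1cc(-c2nnc(SCC(=O)c3ccc(F)cc3)n2N)cc(OC)c1OC` gives 90400 nM.

Compound 3 sits at the lowest of the two numbers shown, yet the step of a 1.0-fold lower number from compound 1 to compound 3 (0.01 log units; within the scatter) lies within the scatter, so compound 3 and compound 1 cannot be ordered. Compound 4 `COc1cc(-c2nnc(SCC(=O)c3ccccc3F)n2N)cc(OC)c1OC` differs from compound 3 by 2-fluorophenyl in place of 4-fluorophenyl on a carbonyl carbon. The measured steps of an at least 1.0-fold higher number from compound 1 to compound 2 (0.03 log units; that floor lies within the scatter) and an at least 1.1-fold lower number from compound 2 to compound 3 (0.04 log units; that floor lies within the scatter) swap one group for another on the aryl ring and all stay within the scatter; none moves a group around the ring. Compound 4 is therefore expected to show a step of a 1.0-fold lower number from compound 3 to compound 4 (0.00 log units; within the scatter), none beyond the scatter, with an estimate of 90000 nM between 40000 nM and 200000 nM.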

Compound 4, half-maximal inhibitory concentration: 22600 nM
The estimate for compound 4 lay 4.0-fold (0.60 log units) above the measured number, and the stated range ends above it.
By their numbers in this assay, from the lowest: compound 4; then compounds 3 and 1 (each within the scatter of the next). At a limit, above all of these: compound 2.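

In this assay, among these compounds, moving the fluorine around the ring gives a 4.0-fold lower number from compound 3 to compound 4 (0.60 log units; beyond the scatter), the first step to pass the scatter, so on this aryl ketone the place of the fluorine counts where exchanging bromo, trifluoromethyl and fluoro showed nothing. The same holds against the bromo compound, with a 4.1-fold lower number from compound 1 to compound 4 (0.61 log units; beyond the scatter). Compound 2 gives only a limit, so an at least 4.4-fold lower number from compound 2 to compound 4 (0.64 log units; beyond the scatter) is a floor: the limit of > 100000 nM in this assay, at which 1 of the 4 values shown sits.

The compounds shown leave open whether this lower number belongs to fluorine itself or would also hold for chloro, methoxy or an amine in its place in 2-fluorophenyl. They also leave open whether a longer chain on the carbonyl carbon would keep it.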